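The source may hold more compounds than are shown below. What is called first, only, known or untested is meant among the compounds shown, and "the series" means these compounds.

Working notes on the series. Compound 1 `COC(=O)c1ccc(-c2cnc(C(=O)CCCCCCc3ccccc3)o2)nc1` gives 3.1 nM in an assay for inhibition of Fatty-acid amide hydrolase 1 (Rattus norvegicus), using a Dixon plot; on this read-out higher numbers stand for weaker inhibition and lower numbers for stronger inhibition. Compound 2 `O=C(CCCCCCc1ccccc1)c1ncc(-c2ccc(CO)cn2)o1` gives 3.2 nM in this assay, and compound 3 `CCOS(=O)(=O)/C=C/c1ccc(-c2cnc(C(=O)CCCCCCc3ccccc3)o2)nc1` gives 2.1 nM in this assay. Compound 2 holds the highest of the three numbers, yet its neighbours lie close: a 1.0-fold higher number from compound 1 to compound 2 (0.01 log units; within the scatter), a 1.5-fold lower number from compound 2 to compound 3 (0.18 log units; within the scatter), and a 1.5-fold lower number from compound 1 to compound 3 (0.17 log units; within the scatter). All three measured steps stay within the scatter.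

Compound 4 `O=C(O)CCCCc1cnc(C(=O)CCCCCCc2ccccc2)o1` is not yet measured. From compound 2 it differs in one place: 4-carboxybutyl in place of 5-(hydroxymethyl)pyridin-2-yl on an aromatic carbon. Among the measured compounds shown here, none of the measured steps bears on this change. Each of them exchanges one group on the six-membered aromatic ring while that ring stays in place; here the whole 5-(hydroxymethyl)pyridin-2-yl leaves and an open 4-carboxybutyl chain enters. The measured steps therefore give no direct guide to the size of this step, and the expectation rests on the change itself. The expected step is a 6.3-fold higher number from compound 2 to compound 4 (0.80 log units; beyond the scatter), toward a higher number and beyond the scatter, with wide uncertainty. For compound 4 the estimated value in this assay is 20 nM, with a range from 4 nM to 100 nM.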

Compound 4, inhibition constant: 23.8 nM
Compound 4: middle estimate off by 1.2-fold (0.08 log units), on the low side; measured number inside the range.
By their numbers in this assay, from the lowest: compounds 3, 1 and 2 (each within the scatter of the next); then compound 4.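

Among the compounds shown here, at this position, on an aromatic carbon next to the ring oxygen, the open 4-carboxybutyl chain in place of the 5-(hydroxymethyl)pyridin-2-yl gives in this assay a 7.4-fold higher number from compound 2 to compound 4 (0.87 log units; beyond the scatter), the only step that lies beyond the scatter. The read-out therefore responds to replacing this whole group, whereas the exchanges on the six-membered aromatic ring among compounds 1, 2 and 3 all stayed within the scatter. No measurement at hand gives a reason for this step.

This single step removes the ring and introduces the carboxylic acid together, so the compounds shown leave open which of the two changes accounts for its size. A plain pentyl chain, or a pyridin-2-yl bearing a carboxylic acid, would separate the two, and a shorter or longer chain ending in a carboxylic acid would test the chain length.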